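Compound 4 from compound 1: an aryl exchange

The source may report more compounds than this note shows. Statements on the series, on what has been measured and on what is new or still open speak of the compounds shown alone.

Compound 1 `COc1ccccc1/C=C/C(=O)OC/C=C/c1cc(OC)c(OC)cc1OC` has been read in a functional assay on the whole organism (strain Kunming) with Mus musculus as the target, with a stated time of 0.5 h, at a dose of 300 mg/kg by the intraperitoneal route (on this read-out lower numbers stand for a stronger effect and higher numbers for a weaker effect at the one dose given), where compound 1 gives 50%. Compound 2 `COc1cc(OC)c(OC)cc1/C=C/COC(=O)/C=C/c1ccccc1C(F)(F)F` gives 50% in this assay, and compound 3 `COc1cccc(/C=C/C(=O)OC/C=C/c2cc(OC)c(OC)cc2OC)c1` gives 50%. Compound 1 therefore stands level with both of them at the digits reported, and every gap among the three lies within the scatter. Two single-point changes from compound 1 have been followed: no change at the digits printed from compound 1 to compound 2 (within the scatter) and no change at the digits printed from compound 1 to compound 3 (within the scatter). The third pair, no change at the digits printed from compound 2 to compound 3 (within the scatter), closes the triangle. None of these moves the read-out beyond the scatter.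

Compound 4 `COc1cc(OC)c(OC)cc1/C=C/COC(=O)/C=C/c1ccc(Cl)cc1` is not yet measured. Against compound 1 it differs thus: 4-chlorophenyl in place of 2-methoxyphenyl on a double-bonded chain carbon bound to a double-bonded chain carbon. This change sits at the same place as the two steps from compound 1 already followed, and both of those were flat. No move beyond the scatter is therefore expected from compound 1 to compound 4 on this read-out. Compound 4 is expected to give 50%, within 35% to 65%. The step this estimate means is expected to be no change at the digits printed from compound 1 to compound 4 (within the scatter).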

Compound 4, a percentage reported as activity, at one dose (the size of the read-out at that dose, not a potency): 25%
Compound 4: the middle estimate sits 25 percentage points above what was measured, outside the stated range (below it).
By their numbers in this assay, from the lowest: compound 4; then compounds 1, 2 and 3 (each within the scatter of the next).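

In this assay the aryl group on a double-bonded chain carbon bound to a double-bonded chain carbon can shift the read-out: placing 4-chlorophenyl in the series in place of 2-methoxyphenyl (a number 25 percentage points lower from compound 1 to compound 4 (beyond the scatter)), 3-methoxyphenyl (a number 25 percentage points lower from compound 3 to compound 4 (beyond the scatter)) or 2-(trifluoromethyl)phenyl (a number 25 percentage points lower from compound 2 to compound 4 (beyond the scatter)) gives a lower number, which is a stronger effect at the one dose. Among these compounds, the flat steps among compounds 1, 2 and 3 therefore did not mean that this place is silent, only that those three groups do not separate from one another. Nothing at hand bears on the reason for this step.

Open, from the compounds shown here alone, is whether the chlorine or the 4-substituted pattern carries the step, which a pair with 4-methoxyphenyl or 2-chlorophenyl could separate. Also open, going by these compounds, is how an aryl group bearing an amine or a carboxylic acid would read at this place.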